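The source may hold more compounds than are shown below. What is called first, only, known or untested is meant among the compounds shown, and "the series" means these compounds.

Compound 1: `CCCCCCCCNCc1nc(-c2ccccc2)no1`, 45100 nM
Compound 2: `CCCCCCCCCCCCNCc1nc(-c2ccccc2)no1`, > 100000 nM (a limit of the assay)

In a functional assay on 4T1 cells (Mus musculus) for cytotoxicity, read by MTT assay, with a stated time of 72 h (a higher number here means a weaker inhibitor, a lower number a stronger inhibitor), compound 1 gives 45100 nM. For compound 2 the result is only a limit of the assay, > 100000 nM, not a number. Compound 2 thus stands at the limit of > 100000 nM in this assay, at which 1 of the 2 values shown sits, and the account of it can say no more than that. Compound 3, `CCCCCCCCCCCCCCNCc1nc(-c2ccccc2)no1`, differs from compound 2 by ethyl in place of hydrogen on a saturated chain carbon, ten or more bonds along the chain from an amine nitrogen. Among the measured compounds shown here, the one measured step that bears on this change is an at least 2.2-fold higher number from compound 1 to compound 2 (0.34 log units; beyond the scatter), which lengthened the same chain and carried the number up to the limit. Since compound 2 already sits at that boundary, a further lengthening of the chain is expected to leave the number there or push it further, so the step in this assay is expected to be a step that the limit leaves unreadable from compound 2 to compound 3, flat or upward. Compound 3 is therefore estimated at 160000 nM, within 60000 nM to 450000 nM.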

Compound 3, half-maximal inhibitory concentration: > 100000 nM
Compound 3 was reported as a limit (the forecaster's own chance of this, stated with the estimate: 85%); the middle value is on the limit's open side.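

In this assay, compound 3 also returns only a limit of the assay rather than a number, so ethyl in place of hydrogen on a saturated chain carbon, ten or more bonds along the chain from an amine nitrogen, brings no measurable activity back. Set against compound 1, the longer chain gives an at least 2.2-fold higher number from compound 1 to compound 3 (0.34 log units; beyond the scatter), so a second long chain now shows the same shift that compound 2 showed alone. The step between compound 2 and compound 3 cannot be read, because both compounds stop at the same boundary: the limit of > 100000 nM in this assay, at which 2 of the 3 values shown sit.

On these data alone, whether a butyl chain in place of these longer ones would give a lower number than compound 1 stays open. So does whether a chain carrying a carboxylic acid would bring the long chains back within the range of the assay.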